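Phenyl in Place of Phenoxy on a Sulfur-Linked Chain

A few compounds are considered here, and "the series" means these few. Any claim that something is new, unique, unknown or untested is made for them only; others in the source may bear on it.

Of the compounds shown here, three that share a core have been tested in an assay on CHO-K1 cells for antagonist activity at transient receptor potential cation channel subfamily V member 1 (Homo sapiens), read by FLIPR; on this read-out lower numbers stand for stronger inhibition and higher numbers for weaker inhibition. Compound 1 `CCCCCSc1nc(C(F)(F)F)ccc1CNC(=O)C(C)c1ccc(NS(C)(=O)=O)c(F)c1` gives 2.5 nM. Compound 2 `CC(C(=O)NCc1ccc(C(F)(F)F)nc1SCCOc1ccccc1)c1ccc(NS(C)(=O)=O)c(F)c1` gives 2.3 nM, and the step of a 1.1-fold lower number from compound 1 to compound 2 (0.04 log units; within the scatter) lies within the scatter, so the two numbers cannot be told apart. Compound 3 `CC(C(=O)NCc1ccc(C(F)(F)F)nc1S(=O)(=O)C1CCCCC1)c1ccc(NS(C)(=O)=O)c(F)c1` was reported as "not active" (no number reported), with no number attached. Compound 2 therefore stands alongside compound 1 as one of two closely matched numbers, with compound 3 set apart by having no number at all.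

Compound 4 `CC(C(=O)NCc1ccc(C(F)(F)F)nc1SCCc1ccccc1)c1ccc(NS(C)(=O)=O)c(F)c1` has not yet been measured. It differs from compound 2 in one place: phenyl in place of phenoxy on a saturated chain carbon, two bonds along the chain from a sulfur. Within the data shown here, no measured step makes this exact exchange. Among the measured compounds shown here, the only step that touches the same place, from propyl to phenoxy, stayed within the scatter, which hints that this position tolerates change, but a single step is thin ground. For compound 4 the expectation is a step of a 1.3-fold higher number from compound 2 to compound 4 (0.12 log units; within the scatter), within the scatter. Compound 4 is thus estimated at 3 nM, with a range from 1 nM to 10 nM.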

Compound 4, inhibition constant: 1.9 nM
For compound 4 the middle estimate is 1.6-fold (0.20 log units) above the measured one, within the range that was stated.
By their numbers in this assay, from the lowest: compounds 4, 2 and 1 (each within the scatter of the next).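

In this assay, the exchange of phenoxy for phenyl gives a 1.2-fold lower number from compound 2 to compound 4 (0.08 log units; within the scatter) and shows that the chain keeps its number without the oxygen that phenoxy carries. The exchange of propyl for phenyl gives a 1.3-fold lower number from compound 1 to compound 4 (0.12 log units; within the scatter) and so adds a direct comparison between a chain ending in an aromatic ring of carbon only and one ending in a saturated carbon chain. Across compound 1, compound 2 and compound 4, this position has so far accepted all three groups with no difference that can be told from the scatter, and no evidence at hand explains this tolerance.

From the compounds shown here alone, whether the position would also accept a chain ending in an amine or a carboxylic acid remains open. So does the outcome with a much longer chain or a pyridine ring in place of phenyl.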